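The source may hold more compounds than are shown below. What is called first, only, known or untested is meant among the compounds shown, and "the series" means these compounds.

Compound 1 `Cn1c(N)c(-c2nc3ccccc3[nH]2)c2nc(C#N)c(C#N)nc21` is the smallest member of this small set. In an ADME assay on HEK293 cells (Homo sapiens) for cytotoxicity, read by MTT assay, with a stated time of 48 h (a higher number here means a weaker inhibitor, a lower number a stronger inhibitor), compound 1 reaches only the limit > 50000 nM, and the limit of > 50000 nM in this assay, at which 1 of the 3 values shown sits, records that one of the three values shown sits there. Compound 2 `CN(C)CCn1c(N)c(-c2nc3ccccc3[nH]2)c2nc(C#N)c(C#N)nc21` gives 9730 nM in this assay, and compound 3 `CN1CCN(CCCn2c(N)c(-c3nc4ccccc4[nH]3)c3nc(C#N)c(C#N)nc32)CC1` gives 6260 nM. The measured steps of an at least 5.1-fold lower number from compound 1 to compound 2 (0.71 log units; beyond the scatter) and an at least 7.9-fold lower number from compound 1 to compound 3 (0.90 log units; beyond the scatter) both move from the limit to a number, whereas a 1.6-fold lower number from compound 2 to compound 3 (0.19 log units; within the scatter) separates the two longer chains only within the scatter. Compound 4 `CCN(CC)CCCCn1c(N)c(-c2nc3ccccc3[nH]2)c2nc(C#N)c(C#N)nc21` has not yet been measured in this assay. It differs from compound 1 by 3-(diethylamino)propyl in place of hydrogen on a saturated chain carbon bound to an aromatic nitrogen. Since the two measured additions at the same place in compound 2 and compound 3 gave much the same outcome, a step of comparable size and direction is expected here, namely an at least 7.1-fold lower number from compound 1 to compound 4 (0.85 log units; beyond the scatter). Compound 4 is therefore estimated to give about 7000 nM in this assay, most likely between 3000 nM and 20000 nM.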

Compound 4, half-maximal inhibitory concentration: 5370 nM
Estimate against measurement, compound 4: 1.3-fold (0.12 log units) above; low and high end bracket the measured number.
By their numbers in this assay, from the lowest: compounds 4, 3 and 2 (each within the scatter of the next). At a limit, above all of these: compound 1.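

In this assay, 3-(diethylamino)propyl on the saturated chain carbon bound to an aromatic nitrogen gives an at least 9.3-fold lower number from compound 1 to compound 4 (0.96 log units; beyond the scatter), so a third chain ending in an amine lies beyond the scatter from compound 1. The size of that step is only a bound, as compound 1 stands at a limit: the limit of > 50000 nM in this assay, at which 1 of the 4 values shown sits. What is new is that the open-chain diethylamino end of compound 4 does not separate from the other two chains, with a 1.2-fold lower number from compound 3 to compound 4 (0.07 log units; within the scatter) and a 1.8-fold lower number from compound 2 to compound 4 (0.26 log units; within the scatter), so neither the kind of amine nor the chain length tells compounds 2, 3 and 4 apart here.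

The compounds shown leave open what a chain of the same length ending in a hydroxyl group or a carboxylic acid would give in place of the amine. They also leave open whether a much longer chain would stay with these three.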